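A Thiazole for an Oxazole on the Sulfonamide Nitrogen

The compounds below may be only part of what the source reports. "The series", "measured", "known", "first", "only" and "open" are said of these compounds alone.

Of the compounds shown here, two built on a shared core have so far been tested in a functional assay on HT-29 cells (Homo sapiens) for antiproliferative activity, read by sulforhodamine B assay, with a stated time of 72 h; a lower number here means a stronger inhibitor, a higher number a weaker inhibitor. Compound 1 `NC(=S)NNc1nncc2ccccc12` gives 47 nM in this assay. Compound 2 `Cc1cc(NS(=O)(=O)c2ccc(Nc3nncc4ccccc34)cc2)no1` gives 23 nM in this assay, the lower of the two numbers, and the gap to compound 1 lies beyond the usual scatter, so compound 2 stands as the stronger inhibitor of the pair.

Compound 3 `O=S(=O)(Nc1nccs1)c1ccc(Nc2nncc3ccccc23)cc1` has not yet been measured. It differs from compound 2 in one place: 1,3-thiazol-2-yl in place of 5-methyl-1,2-oxazol-3-yl on a sulfonamide nitrogen. One five-membered aromatic ring with 2 hetero atoms gives way to another five-membered aromatic ring with 2 hetero atoms, each carrying 0 hydrogen-bond donors and 2 hydrogen-bond acceptors, and the change sits on a sulfonamide nitrogen whose other neighbour is the sulfonyl sulfur.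

Among the compounds with values here, no measured pair shows a change of this kind, so the expectation rests on its small size alone. The step of a 1.3-fold higher number from compound 2 to compound 3 (0.12 log units; within the scatter) is expected to stay within the usual scatter, in no firm direction. Compound 3 is therefore estimated at 30 nM in this assay, with a likely range from 12 nM to 80 nM.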

Compound 3, half-maximal inhibitory concentration: 34 nM
For compound 3 the middle estimate is 1.1-fold (0.05 log units) below the measured one; the range from low to high includes it.
By their numbers in this assay, from the lowest: compounds 2, 3 and 1 (each within the scatter of the next, the first and the last beyond it).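

In this assay, within the data shown here, putting 1,3-thiazol-2-yl in place of 5-methyl-1,2-oxazol-3-yl on the sulfonamide nitrogen gives a 1.5-fold higher number from compound 2 to compound 3 (0.17 log units; within the scatter), and this is the first measured step at this position. The position therefore accepts one five-membered aromatic ring with 2 hetero atoms in place of another without a shift beyond the usual scatter, even though the methyl group leaves and a ring sulfur enters where a ring oxygen stood. No accompanying measurement bears on this result, so it stands as an observation about these two compounds alone.

As far as these compounds go, how far this tolerance extends remains open, since both rings belong to the same broad type, and a pyridine ring, a phenyl ring or a plain hydrogen on the same sulfonamide nitrogen could give a very different number. Among these compounds, the single step also changes the ring and removes the methyl group together, so their separate contributions cannot be read from it, and a methyl group on the 1,3-thiazol-2-yl ring would be needed to pull them apart.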